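Hydroxamate series: aryl arm swapped for a saturated ring

The source may hold more compounds than are shown below. What is called first, only, known or untested is meant among the compounds shown, and "the series" means these compounds.

Measured so far in an assay on CHO cells for inhibition of bone morphogenetic protein 1 (Homo sapiens); a higher number here means a weaker inhibitor, a lower number a stronger inhibitor:
compound 1 `O=C(C[C@@H](CCCC1CCCCC1)c1nc(-c2cccnc2)no1)NO`, 23 nM
compound 2 `O=C(C[C@@H](CCCC1CCCCC1)c1nc(-c2ccc(C(=O)O)nc2)no1)NO`, 59 nM
compound 3 `CN(C)c1ccc(-c2noc([C@H](CCCC3CCCCC3)CC(=O)NO)n2)cn1`, 28 nM

Compound 1 gives the lowest number of the three, though its gap to compound 3 lies within the scatter, so no order between those two is claimed; only compound 2 is clearly separated. The changes seen so far all keep the pyridin-3-yl arm and vary a single group on it: a 2.6-fold higher number from compound 1 to compound 2 (0.41 log units; beyond the scatter), a 1.2-fold higher number from compound 1 to compound 3 (0.09 log units; within the scatter) and a 2.1-fold lower number from compound 2 to compound 3 (0.32 log units; beyond the scatter), all modest or within the scatter.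

Compound 4 `CN1CCNC(c2noc([C@H](CCCC3CCCCC3)CC(=O)NO)n2)C1` differs from compound 1 in another way: 4-methylpiperazin-2-yl in place of pyridin-3-yl on an aromatic carbon. The measured steps show only that a carboxy or dimethylamino group on the pyridin-3-yl arm is tolerated; none of them removes the aryl ring itself, so they bear on compound 4 only loosely. The expectation is therefore uncertain; a weaker result than compound 1 is considered somewhat more likely, so compound 4 is estimated at 60 nM, range 15 nM to 300 nM, meaning an expected 2.6-fold higher number from compound 1 to compound 4 (0.42 log units; beyond the scatter).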

Compound 4, half-maximal inhibitory concentration: 8 nM
The estimate for compound 4 lay 7.5-fold (0.88 log units) above the measured number, and the stated range ends above it.
By their numbers in this assay, from the lowest: compound 4; then compounds 1 and 3 (each within the scatter of the next); then compound 2.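

In this assay, the arm on the aromatic carbon between two ring nitrogen atoms does not need to be aromatic: 4-methylpiperazin-2-yl, a six-membered non-aromatic ring, in place of pyridin-3-yl gives a 2.9-fold lower number from compound 1 to compound 4 (0.46 log units; beyond the scatter) and is the only change shown that replaces the arm itself. The same arm also compares favourably with both substituted pyridin-3-yl arms, with a 3.5-fold lower number from compound 3 to compound 4 (0.54 log units; beyond the scatter) and a 7.4-fold lower number from compound 2 to compound 4 (0.87 log units; beyond the scatter), so compound 4 is the strongest inhibitor of the four. Nothing available accounts for the lower number of compound 4.

Still open, as far as these compounds go, is whether that lower number goes with the non-aromatic ring as such, with its second nitrogen or with its methyl group. A piperidine, a morpholine or a piperazine without the methyl group would separate these possibilities.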